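Chain-shortened benzamide series against HeLa proliferation

The source may hold more compounds than are shown below. What is called first, only, known or untested is meant among the compounds shown, and "the series" means these compounds.

Measured compounds:
compound 1 `CCOc1cc(NC(=O)CCCCCCC(=O)Nc2ccccc2N)cc2c1OCC([N+](=O)[O-])=C2` — > 20000 nM
compound 2 `CCOc1cc(NC(=O)CCCCCCC(=O)Nc2cc(-c3ccc(C)s3)ccc2N)cc2c1OCC([N+](=O)[O-])=C2` — > 20000 nM
compound 3 `CCOc1cc(NC(=O)CCCCC(=O)Nc2cc(-c3ccc(C)s3)ccc2N)cc2c1OCC([N+](=O)[O-])=C2` — 18400 nM

In a functional assay on HeLa cells (Homo sapiens) for antiproliferative activity, read by MTT assay, with a stated time of 48 h (a higher number here means a weaker inhibitor of growth, a lower number a stronger inhibitor of growth), compound 1 reaches only a limit of the assay, > 20000 nM. Compound 2 likewise returns a limit, > 20000 nM, in this assay. Among the compounds with values here, compound 3 is the one member with a number, giving 18400 nM in this assay. The difference between the cores of compound 2 and compound 3 is not broken down here.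

From compound 2 to compound 1 the change is hydrogen in place of 5-methylthiophen-2-yl on an aromatic carbon; the step that the two limits leave unreadable from compound 2 to compound 1 cannot be read, as the limit of > 20000 nM in this assay, at which 2 of the 3 values shown sit, sets the limit at which both values sit.

Compound 4 `CCOc1cc(NC(=O)CCCCC(=O)Nc2ccccc2N)cc2c1OCC([N+](=O)[O-])=C2` is not yet measured. From compound 3 to compound 4 the change is hydrogen in place of 5-methylthiophen-2-yl on an aromatic carbon, the same change as from compound 2 to compound 1, at the same place. Since that earlier step is unreadable, the expectation for compound 4 rests on compound 3 alone, whose value is 18400 nM. Compound 4 is therefore expected to be similarly weak, with an estimated step of a 1.4-fold higher number from compound 3 to compound 4 (0.13 log units; within the scatter). The estimate for compound 4 in this assay is 25000 nM, between 9000 nM and 70000 nM.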

Compound 4, concentration for 50% growth inhibition: 13100 nM
Compound 4: the middle estimate sits 1.9-fold (0.28 log units) above what was measured; the measured number falls inside the stated range.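

In this assay, hydrogen in place of 5-methylthiophen-2-yl on the core of compound 3 gives a 1.4-fold lower number from compound 3 to compound 4 (0.15 log units; within the scatter), so on this core the pair cannot be told apart. The same change on the core of compound 2 cannot be read, as both of its ends are limits of the assay and not numbers: the limit of > 20000 nM in this assay, at which 2 of the 4 values shown sit. Carrying the change from one core to the other therefore remains untested, with a single readable step that shows nothing about the size of the change on the core of compound 2 and offers no second step to compare it with.

Open, as far as these compounds go, is whether an amine or a carboxylic acid on that aromatic carbon would give a step beyond the scatter from compound 4 in this assay. Also open, from the compounds shown here alone, is how a chain shorter than that of compound 4 would read in this assay, with or without the 5-methylthiophen-2-yl group.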